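The source may hold more compounds than are shown below. What is called first, only, known or untested is meant among the compounds shown, and "the series" means these compounds.

Three compounds sharing one core were tested in a functional assay on MCF7 cells (Homo sapiens) for antiproliferative activity, read by MTT assay, with stated times of 24 h and 72 h; on this read-out lower numbers stand for stronger inhibition and higher numbers for weaker inhibition. Compound 1 `COc1ccc([C@@H]2[C@H](Oc3ccccc3)C(=O)N2c2cc(OC)c(OC)c(OC)c2)cc1` gives 35000 nM. Compound 2 `COc1ccc([C@@H]2[C@H](Oc3ccccc3)C(=O)N2c2cc(OC)c(OC)c(OC)c2)cc1OC` gives 26000 nM, and compound 3 `COc1cc(N2C(=O)[C@@H](Oc3ccccc3)[C@H]2c2ccc(O)cc2)cc(OC)c1OC` gives 48000 nM. The step of a 1.3-fold lower number from compound 1 to compound 2 (0.13 log units; within the scatter) comes from the change (methoxy in place of hydrogen on an aromatic carbon). The step of a 1.4-fold higher number from compound 1 to compound 3 (0.14 log units; within the scatter) comes from the change (hydrogen in place of methyl on an oxygen on an aromatic ring), and the step of a 1.8-fold higher number from compound 2 to compound 3 (0.27 log units; within the scatter) completes the set; all three lie within the scatter, so no ordering among the three is claimed.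

Compound 4 `COc1cc([C@@H]2[C@H](Oc3ccccc3)C(=O)N2c2cc(OC)c(OC)c(OC)c2)ccc1O` has not yet been measured. It differs from compound 3 by methoxy in place of hydrogen on an aromatic carbon. This is the same kind of change as that from compound 1 to compound 2, where it gave a 1.3-fold lower number from compound 1 to compound 2 (0.13 log units; within the scatter); the two cores differ by hydrogen in place of methyl on an oxygen on an aromatic ring, and the place is not identical, since in compound 2 the entering group is ortho to a methoxy group (2 heavy atoms) while in compound 4 it is ortho to a hydroxy group (1 heavy atom). For compound 4 the expected step is a 1.3-fold lower number from compound 3 to compound 4 (0.12 log units; within the scatter), resting on the earlier step of a 1.3-fold lower number from compound 1 to compound 2 (0.13 log units; within the scatter). Compound 4 is therefore estimated at 36000 nM, with the expected range running from 18000 nM to 72000 nM.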

Compound 4, half-maximal inhibitory concentration: 32000 nM
Compound 4: the middle estimate sits 1.1-fold (0.05 log units) above what was measured; the measured number falls inside the stated range.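

In this assay, methoxy in place of hydrogen on an aromatic carbon gives a 1.5-fold lower number from compound 3 to compound 4 (0.18 log units; within the scatter), and this step matches the earlier one on the other core: the same change on two cores in this assay, a 1.3-fold lower number (0.13 log units; within the scatter) from compound 1 to compound 2 and a 1.5-fold lower number (0.18 log units; within the scatter) from compound 3 to compound 4, 1.1-fold (0.05 log units) apart, within the scatter of two such steps. Hydrogen in place of methyl on an oxygen gives a 1.2-fold higher number from compound 2 to compound 4 (0.09 log units; within the scatter), and this step likewise matches its earlier counterpart: the same change on two cores in this assay, a 1.4-fold higher number (0.14 log units; within the scatter) from compound 1 to compound 3 and a 1.2-fold higher number (0.09 log units; within the scatter) from compound 2 to compound 4, 1.1-fold (0.05 log units) apart, within the scatter of two such steps. Both changes therefore read the same on the two cores, and the replacement of 4-methoxyphenyl by 4-hydroxy-3-methoxyphenyl gives a 1.1-fold lower number from compound 1 to compound 4 (0.04 log units; within the scatter), but every one of these steps lies within the scatter, so the series shows no detectable effect of either change rather than a real effect of fixed size carried from core to core.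

On the varied phenyl ring, the four compounds carry only methoxy and hydroxy groups. Going by these compounds, whether an amine, a carboxylic acid, a fluorine atom or a longer chain such as ethoxy at that ring would give a step beyond the scatter remains open.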